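Swapping pyridin-2-yl for pyridin-3-yl in a small series

The source may hold more compounds than are shown below. What is called first, only, known or untested is meant among the compounds shown, and "the series" means these compounds.

Measured so far in a physicochemical assay for lipophilicity, in phosphate buffer, measured as octanol-water partition, at pH 7.4; a lower number here means a more polar compound, a higher number a more lipophilic compound:
- compound 1 `O=C(CN1CCN(c2cccc(F)c2)CC1)Nc1nc2c(s1)CCCC2`: "not determined" (no result reported)
- compound 2 `O=C(CN1CCN(c2ccc(F)cn2)CC1)Nc1nc2c(s1)CCCC2`: 4.1
- compound 3 `O=C(CN1CCN(c2ccccn2)CC1)Nc1nc2c(s1)CCCC2`: 3.9

In this assay compound 3 gives 3.9, and this lies within the usual scatter of compound 2 at 4.1. Within the data shown here, compound 1 offers no number for comparison, so only two values are available.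

The next candidate is compound 4 `O=C(CN1CCN(c2cccnc2)CC1)Nc1nc2c(s1)CCCC2`, which has not yet been measured. It carries pyridin-3-yl in place of pyridin-2-yl on an amine nitrogen in a ring. The rest of the structure matches compound 3.

Among the measured compounds shown here, only one measured step is available as a guide: a number 0.20 log units lower from compound 2 to compound 3 (within the scatter). That step is a different kind of change, hydrogen in place of fluoro on an aromatic carbon, so it bears on the new change only indirectly. For the measured compounds named here, no measured pair shows this exchange of pyridinyl groups directly, which leaves the expectation loose. A small step with a slight downward lean, not beyond the scatter, seems most likely. The expected step is a number 0.20 log units lower from compound 3 to compound 4 (within the scatter). The estimate for compound 4 is 3.7, with an expected range from 3.3 to 4.1.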

Compound 4, distribution coefficient: 3.3
For compound 4 the middle estimate is 0.40 log units above the measured one; the range from low to high includes it.
By their numbers in this assay, from the lowest: compound 4; then compounds 3 and 2 (each within the scatter of the next).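

In this assay, pyridin-3-yl in place of pyridin-2-yl on an amine nitrogen in a ring gives a number 0.60 log units lower from compound 3 to compound 4 (beyond the scatter) even though the two compounds have the same atoms, joined differently, so at this place the way the pyridine ring is attached can shift the reading with no change in its atoms. Pyridin-3-yl in place of 5-fluoropyridin-2-yl gives a number 0.80 log units lower from compound 2 to compound 4 (beyond the scatter) and sets compound 4 apart from both compounds that carry a pyridin-2-yl type ring, whereas the earlier fluoro-to-hydrogen step alone had not separated any two compounds in this series. Nothing available here accounts for the size of this step.

Among these compounds, compound 1 has no number, so no step involving it can be read. Still open, from the compounds shown here alone, is how pyridin-4-yl or a plain phenyl group would read in this assay at this same place, and whether the step from pyridin-2-yl to pyridin-3-yl would recur with a fluoro group on the ring or on a different core.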